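Swapping Bromo for Dimethylcarbamoyl on the Fused Core

This account rests on a few compounds, and the source may have more. Where it says the series, first, only, none or still open, it means among the compounds named here.

For the measured compounds named here, compound 3 `Cc1ccc([N+](=O)[O-])cc1S(=O)(=O)N(C)/N=C/c1cnn2ccc(Br)cc12` is the only compound here with an actual number: in an assay on isolated protein for inhibition of phosphatidylinositol 4,5-bisphosphate 3-kinase catalytic subunit beta isoform (Homo sapiens), read by 33P incorporation, with a stated time of 60 min (on this read-out lower numbers stand for stronger inhibition and higher numbers for weaker inhibition), compound 3 gives 230 nM. Compound 1 `COc1ccn2ncc(/C=N/N(C)S(=O)(=O)c3cc([N+](=O)[O-])ccc3C)c2c1` reaches only a limit of the assay, and in this assay compound 1 gives > 1000 nM. Compound 2 `CC(=O)Oc1ccn2ncc(/C=N/N(C)S(=O)(=O)c3cc([N+](=O)[O-])ccc3C)c2c1` likewise stops at a limit, and in this assay compound 2 gives > 1000 nM. That ceiling is the limit of > 1000 nM in this assay, at which 2 of the 3 values shown sit. The step of an at least 4.3-fold lower number from compound 1 to compound 3 (0.63 log units; beyond the scatter) and the step of an at least 4.3-fold lower number from compound 2 to compound 3 (0.63 log units; beyond the scatter) show that the group on this aromatic carbon of the core moves the number, while a step that the two limits leave unreadable from compound 1 to compound 2 cannot be read.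

Compound 4 `Cc1ccc([N+](=O)[O-])cc1S(=O)(=O)N(C)/N=C/c1cnn2ccc(C(=O)N(C)C)cc12` differs from compound 3 by dimethylcarbamoyl in place of bromo on an aromatic carbon. Going by the values given here, no measured step compares bromo with dimethylcarbamoyl. With an at least 4.3-fold lower number from compound 1 to compound 3 (0.63 log units; beyond the scatter) and an at least 4.3-fold lower number from compound 2 to compound 3 (0.63 log units; beyond the scatter) showing bromo giving a lower number than the other groups tried there, compound 4 is expected to come out somewhat weaker, with a step of a 2.2-fold higher number from compound 3 to compound 4 (0.34 log units; beyond the scatter). Compound 4 is estimated at 500 nM, with a range from 150 nM to 2000 nM.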

Compound 4, half-maximal inhibitory concentration: > 1000 nM
Compound 4: no number, only a limit; the forecaster's own chance of this, stated with the estimate: 30%; middle value at least 2.0-fold (0.30 log units) away from the limit.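

In this assay, dimethylcarbamoyl in place of bromo gives an at least 4.3-fold higher number from compound 3 to compound 4 (0.63 log units; beyond the scatter). So a third replacement for bromo on this aromatic carbon, and the only one with more heavy atoms in a carbonyl-bearing amide group, also loses ground against compound 3, which remains the only compound with a number rather than a limit. Compound 4 joins compound 1 and compound 2 at the same ceiling, so the steps among these three cannot be read and methoxy, acetoxy and dimethylcarbamoyl cannot be ranked against one another: the limit of > 1000 nM in this assay, at which 3 of the 4 values shown sit.

Still open, on these data alone, is whether bromo itself matters, or whether chloro, iodo or a plain methyl would do as well or better here. Also open, as far as these compounds go, is whether a smaller amide, such as the unsubstituted carboxamide, would stay measurable.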